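Cutting the long chain of compound 2

A few compounds are considered here, and "the series" means these few. Any claim that something is new, unique, unknown or untested is made for them only; others in the source may bear on it.

Measured in a functional assay on the whole organism with Mus musculus as the target, in the rotarod test; a higher number here means that more compound is needed for the effect, a lower number that less compound is needed:
- compound 1 `CCCCCC(=O)NCC(=O)N(C)c1ccc(Cl)cc1C(=O)c1ccccc1Cl`: 90 mg/kg
- compound 2 `CCCCCCCCCCCCCCCC(=O)NCC(=O)N(C)c1ccc(Cl)cc1C(=O)c1ccccc1Cl`: > 100 mg/kg (a limit, not a number)

Compound 2 stands at the limit of > 100 mg/kg in this assay, at which 1 of the 2 values shown sits. Its true value is therefore not known. Compound 3 `CCCCC(=O)NCC(=O)N(C)c1ccc(Cl)cc1C(=O)c1ccccc1Cl` differs from compound 2 as follows: hydrogen in place of undecyl on a saturated chain carbon, four bonds along the chain from a carbonyl carbon. This puts hydrogen in place of undecyl on a saturated chain carbon, four bonds along the chain from a carbonyl carbon.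

Among the measured compounds shown here, one measured step bears on this change: an at least 1.1-fold higher number from compound 1 to compound 2 (0.04 log units; that floor lies within the scatter). It put decyl in place of hydrogen on a saturated chain carbon, five bonds along the chain from a carbonyl carbon. The new change removes a long chain in a similar way, so a value close to that of compound 1 at 90 mg/kg is expected. The expected step is an at least 1.1-fold lower number from compound 2 to compound 3 (0.07 log units; that floor lies within the scatter), toward a lower number but not beyond the scatter. For compound 3 the estimate is 85 mg/kg, with an expected range from 45 mg/kg to 160 mg/kg.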

Compound 3, dose for half-maximal effect: 90 mg/kg
Estimate against measurement, compound 3: 1.1-fold (0.02 log units) below; low and high end bracket the measured number.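

Hydrogen in place of methyl on this saturated chain carbon, four bonds along the chain from a carbonyl carbon, leaves the dose in this assay where it was, with no change at the digits printed from compound 1 to compound 3 (within the scatter), so these two short chains cannot be told apart in this test. Hydrogen in place of undecyl gives an at least 1.1-fold lower number from compound 2 to compound 3 (0.04 log units; that floor lies within the scatter), which is only a floor for the true step. The value of compound 2 is a limit and not a number, so the effect of removing the long chain remains unknown: the limit of > 100 mg/kg in this assay, at which 1 of the 3 values shown sits.

The compounds shown leave open whether a much shorter chain, such as ethyl, would move the dose beyond the scatter. They also leave open what an amine or a carboxylic acid on this chain would do.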